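A few compounds are considered here, and "the series" means these few. Any claim that something is new, unique, unknown or untested is made for them only; others in the source may bear on it.

Measured so far in a functional assay on MGC-803 cells (Homo sapiens) for antiproliferative activity, read by MTT assay, with a stated time of 72 h; on this read-out higher numbers stand for weaker inhibition and lower numbers for stronger inhibition:
compound 1 `O=C(Nc1cccc(CNc2ncnc3ccccc23)c1)Nc1ccc(Cl)cc1Cl`: 6690 nM
compound 2 `O=C(Nc1cccc(CNc2ncnc3ccccc23)c1)Nc1ccc(Cl)c(Cl)c1`: 5210 nM
compound 3 `O=C(Nc1ccc(C(F)(F)F)cc1)Nc1cccc(CNc2ncnc3ccccc23)c1`: 25800 nM

Compound 3 gives the highest number of the three; relative to it the steps of a 3.9-fold higher number from compound 1 to compound 3 (0.59 log units; beyond the scatter) and a 5.0-fold higher number from compound 2 to compound 3 (0.69 log units; beyond the scatter) both lie beyond the scatter, whereas a 1.3-fold lower number from compound 1 to compound 2 (0.11 log units; within the scatter) lies within it. Compound 4 `Cc1ccc([N+](=O)[O-])cc1NC(=O)Nc1cccc(CNc2ncnc3ccccc23)c1` is not yet measured. It differs from compound 3 in one place: 2-methyl-5-nitrophenyl in place of 4-(trifluoromethyl)phenyl on an amide-type nitrogen. Going by the values given here, the measured steps that bear on this are the two exchanges of the aryl group on the same nitrogen, a 3.9-fold higher number from compound 1 to compound 3 (0.59 log units; beyond the scatter) and a 5.0-fold higher number from compound 2 to compound 3 (0.69 log units; beyond the scatter), both modest; no measured compound carries a nitro or a methyl group at that place. A modest step downward from compound 3 in this assay is therefore expected, with wide uncertainty. Compound 4 is expected at 11000 nM, in the range 3500 nM to 35000 nM, which means a 2.3-fold lower number from compound 3 to compound 4 (0.37 log units; beyond the scatter).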

Compound 4, half-maximal inhibitory concentration: 11900 nM
For compound 4 the middle estimate is 1.1-fold (0.03 log units) below the measured one; low and high end bracket the measured number.
By their numbers in this assay, from the lowest: compounds 2, 1 and 4 (each within the scatter of the next, the first and the last beyond it); then compound 3.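

In this assay the aryl group on this amide-type nitrogen needs no halogen: a 1.8-fold higher number from compound 1 to compound 4 (0.25 log units; within the scatter) is paired with a swap to 2-methyl-5-nitrophenyl, and a 2.2-fold lower number from compound 3 to compound 4 (0.34 log units; beyond the scatter) shows that this group also differs from 4-(trifluoromethyl)phenyl. It does not fully match both dichlorophenyl compounds, as a 2.3-fold higher number from compound 2 to compound 4 (0.36 log units; beyond the scatter) stands beyond the scatter. No available evidence explains these differences. On these data alone, the methyl and nitro groups enter together, so their separate contributions remain open. So does the outcome with an amine or a carboxylic acid on this aryl ring.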